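Changing the aryl group on the ring nitrogen of compound 2

The source may report more compounds than this note shows. Statements on the series, on what has been measured and on what is new or still open speak of the compounds shown alone.

In a functional assay on A549 cells (Homo sapiens) for cytotoxicity, read by MTT assay, with a stated time of 72 h (on this read-out lower numbers stand for stronger inhibition and higher numbers for weaker inhibition), compound 2 `Cc1ccc(-n2nc(C(=O)Nc3ccc(Oc4ncnc5[nH]ccc45)cc3)c(C)cc2=O)cc1` gives 6400 nM.
In this assay compound 1 `Cc1cc(=O)n(-c2cccc(F)c2)nc1C(=O)Nc1ccc(Oc2ncnc3[nH]ccc23)cc1` gives 34800 nM.

Compound 2 has the lowest of the two numbers; its nearest neighbour is compound 1, and the step from compound 1 to compound 2 is a 5.4-fold lower number from compound 1 to compound 2 (0.74 log units; beyond the scatter). Compound 3 `Cc1cc(=O)n(-c2ccccc2OC(F)(F)F)nc1C(=O)Nc1ccc(Oc2ncnc3[nH]ccc23)cc1` differs from compound 2 by 2-(trifluoromethoxy)phenyl in place of 4-methylphenyl on an aromatic nitrogen. Within the data shown here, only that one step bears on this change, and it shows that the group on the aromatic nitrogen matters. Nothing measured covers the entering group, so a step of a 1.9-fold higher number from compound 2 to compound 3 (0.27 log units; within the scatter) in this assay is estimated, back toward compound 1. Compound 3 is therefore expected at 12000 nM, within 3000 nM to 50000 nM.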

Compound 3, half-maximal inhibitory concentration: 16200 nM
Estimate against measurement, compound 3: 1.4-fold (0.13 log units) below; low and high end bracket the measured number.
By their numbers in this assay, from the lowest: compound 2; then compound 3; then compound 1.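

In this assay, a third aryl group on the aromatic nitrogen, 2-(trifluoromethoxy)phenyl, gives a result that falls in the gap left by the first two compounds (step: a 2.5-fold higher number from compound 2 to compound 3 (0.40 log units; beyond the scatter)) and (step: a 2.1-fold lower number from compound 1 to compound 3 (0.33 log units; beyond the scatter)). All three compounds now stand apart by more than the usual scatter, with compound 2 lowest and compound 1 highest, so this position responds to each of these aryl groups. Nothing available explains this order.

Each aryl group differs from the others in both its substituent and where that substituent sits, so these two influences cannot yet be separated. From the compounds shown here alone, how a plain phenyl group, or a phenyl group carrying an amine or a carboxylic acid, would compare remains open.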